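Returning to the five-membered ring, now bearing chlorine

This account rests on a few compounds, and the source may have more. Where it says the series, first, only, none or still open, it means among the compounds named here.

Compound 1 `Nc1ccccc1NC(=O)c1ccc(CSC(=S)N2CCc3ccccc32)cc1` gives 67% in a functional assay on HeLa cells (Homo sapiens) for antiproliferative activity, read by CCK-8 assay, with a stated time of 72 h, tested at 8 uM (on this read-out higher numbers stand for a stronger effect at the one concentration tested and lower numbers for a weaker effect), compound 2 `CN(C(=S)SCc1ccc(C(=O)Nc2ccccc2N)cc1)c1cccnc1` gives 70.5%, and compound 3 `Nc1ccccc1NC(=O)c1ccc(CSC(=S)N2CCCc3ccccc32)cc1` gives 35.7%, the lowest of the three. Compound 4 `Nc1ccccc1NC(=O)c1ccc(CSC(=S)N2CCc3cc(Cl)ccc32)cc1` is not yet measured; it differs from compound 3 in one place: 5-chloro-2,3-dihydro-1H-indol-1-yl in place of 1,2,3,4-tetrahydroquinolin-1-yl on a thiocarbonyl carbon. The measured step that bears on this is a number 31.3 percentage points lower from compound 1 to compound 3 (beyond the scatter), which exchanged the 2,3-dihydro-1H-indol-1-yl group of compound 1 for the 1,2,3,4-tetrahydroquinolin-1-yl group of compound 3. Within the data shown here, compound 4 reverses that exchange and carries a chlorine as well, and no measured compound shows what that chlorine does. Compound 4 is therefore expected to show a large rise, a number 29.3 percentage points higher from compound 3 to compound 4 (beyond the scatter). Compound 4 is estimated at 65%, within 45% to 82%.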

Compound 4, a percentage reported as inhibition, at one concentration (the size of the read-out at that concentration, not a potency): 65.1%
Beside the measured number, compound 4's estimate is 0.1 percentage points below it; low and high end bracket the measured number.
By their numbers in this assay, from the lowest: compound 3; then compounds 4, 1 and 2 (each within the scatter of the next).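

In this assay, chloro in place of hydrogen on an aromatic carbon gives a step that cannot be told from repeat scatter, a number 1.9 percentage points lower from compound 1 to compound 4 (within the scatter), so this ring tolerates the chlorine. With the chlorine on board, the five-membered ring still stands clear of the 1,2,3,4-tetrahydroquinolin-1-yl group, a number 29.4 percentage points higher from compound 3 to compound 4 (beyond the scatter), and compares with methyl(pyridin-3-yl)amino as a number 5.4 percentage points lower from compound 2 to compound 4 (within the scatter). Nothing measured here explains these steps.

On these data alone, it remains open whether a methoxy group or an amine in the chlorine's place would hold this level. Chlorine on the 1,2,3,4-tetrahydroquinolin-1-yl group also remains open.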